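This account rests on a few compounds, and the source may have more. Where it says the series, first, only, none or still open, it means among the compounds named here.

In a functional assay (on this read-out lower numbers stand for stronger inhibition and higher numbers for weaker inhibition), three chlorophenyl compounds on one shared core have been measured: compound 1 `CC(C)=CCOc1cc(O)c2c(c1)OC(c1ccccc1Cl)CC2=O` gives 4270 nM, compound 2 `CC(C)=CCOc1cc(O)c2c(c1)OC(c1cccc(Cl)c1)CC2=O` gives 6060 nM and compound 3 `CC(C)=CCOc1cc(O)c2c(c1)OC(c1ccc(Cl)cc1)CC2=O` gives 7020 nM. Compound 3 cannot be told apart from the other two. Its steps are a 1.2-fold higher number from compound 2 to compound 3 (0.06 log units; within the scatter) and a 1.6-fold higher number from compound 1 to compound 3 (0.22 log units; within the scatter), and the remaining pair shows a 1.4-fold higher number from compound 1 to compound 2 (0.15 log units; within the scatter).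

Compound 4 `CC(C)=CCOc1cc(O)c2c(c1)OC(c1cccc(Br)c1)CC2=O` has not yet been measured. Its difference from compound 3 is 3-bromophenyl in place of 4-chlorophenyl on a saturated ring carbon, next to the ring oxygen.

Going by the values given here, no measured step exchanges chlorine for bromine, so that part of the change remains untested. Among the compounds with values here, the steps that bear on it are those that change the chlorophenyl group, and all three are small. The closest reference is compound 2 at 6060 nM, whose 3-chlorophenyl group is the counterpart of the 3-bromophenyl group. On this basis, no step beyond the scatter is expected in this assay. The estimated change is a 1.3-fold lower number from compound 3 to compound 4 (0.11 log units; within the scatter). Compound 4 is expected at 5500 nM, with an estimated range from 2800 nM to 10500 nM.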

Compound 4, half-maximal inhibitory concentration: 4040 nM
Estimate against measurement, compound 4: 1.4-fold (0.13 log units) above; the range from low to high includes it.
By their numbers in this assay, from the lowest: compounds 4, 1, 2 and 3 (each within the scatter of the next).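

In this assay the exchange of bromo for chloro on an aromatic carbon now has a measured step of its own (a 1.5-fold lower number from compound 2 to compound 4 (0.18 log units; within the scatter)), and this step lies within the scatter, so the one direct test of the halogen separates neither compound from the other. The two steps that change the halogen and its place on the phenyl ring together (a 1.7-fold lower number from compound 3 to compound 4 (0.24 log units; within the scatter) and a 1.1-fold lower number from compound 1 to compound 4 (0.02 log units; within the scatter)) also lie within the scatter, even though the first of them is the largest step among the four compounds. At this saturated ring carbon, next to the ring oxygen, the read-out therefore does not distinguish 3-bromophenyl from any of the three chlorophenyl groups.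

From the compounds shown here alone, all four compounds carry a single halogen on the phenyl ring, so it remains open whether an amine, a carboxylic acid or a methoxy group in place of that halogen would also stay within the scatter, and whether bromine would do so in the places that chlorine holds in compound 1 and compound 3. Nothing measured here offers an explanation for any of these steps.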